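The compounds below may be only part of what the source reports. "The series", "measured", "known", "first", "only" and "open" are said of these compounds alone.

compound 1 `COc1ccc(CN(C(=O)Cn2cc(COc3ccccc3)nn2)c2cc(OC)c(OC)c(OC)c2)cc1`: 45300 nM
compound 2 `COc1ccc(CN(C(=O)Cn2cc(CSc3nncs3)nn2)c2cc(OC)c(OC)c(OC)c2)cc1`: 16500 nM
compound 3 `COc1ccc(CN(C(=O)Cn2cc(CSc3nnnn3C)nn2)c2cc(OC)c(OC)c(OC)c2)cc1`: 10900 nM

These values come from a functional assay on PC-3 cells (Homo sapiens) for antiproliferative activity, read by MTT assay, with a stated time of 48 h; on this read-out higher numbers stand for weaker inhibition and lower numbers for stronger inhibition. Compound 3 has the lowest number of the three, but it cannot be separated from its nearest neighbour, the step being a 1.5-fold lower number from compound 2 to compound 3 (0.18 log units; within the scatter). It stands clear of the phenoxy analogue, with a 4.2-fold lower number from compound 1 to compound 3 (0.62 log units; beyond the scatter).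

Compound 4 `COc1ccc(CN(C(=O)Cn2cc(CNS(=O)(=O)c3ccc(C)cc3)nn2)c2cc(OC)c(OC)c(OC)c2)cc1` has not yet been measured. It carries ((4-methylphenyl)sulfonyl)amino in place of (1-methyl-1H-tetrazol-5-yl)sulfanyl on a saturated chain carbon bound to an aromatic carbon.

Among the measured compounds shown here, no measured step tests a sulfonylamino group, so the guidance is indirect. The closest evidence is the pair of modest steps away from phenoxy, a 2.7-fold lower number from compound 1 to compound 2 (0.44 log units; beyond the scatter) and a 4.2-fold lower number from compound 1 to compound 3 (0.62 log units; beyond the scatter). For the measured compounds named here, compound 4 regains a six-membered aromatic ring of carbon only, so a modest move back toward compound 1 is expected in this assay, with no larger step than those. The expected change is a 2.2-fold higher number from compound 3 to compound 4 (0.34 log units; beyond the scatter). For compound 4 the estimated value is 24000 nM, with an expected range of 7000 nM to 70000 nM.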

Compound 4, half-maximal inhibitory concentration: 12400 nM
Beside the measured number, compound 4's estimate is 1.9-fold (0.29 log units) above it, within the range that was stated.
By their numbers in this assay, from the lowest: compounds 3, 4 and 2 (each within the scatter of the next); then compound 1.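

In this assay, the place on a saturated chain carbon bound to an aromatic carbon takes ((4-methylphenyl)sulfonyl)amino without a separable change from either sulfanyl-linked group (a 1.1-fold higher number from compound 3 to compound 4 (0.06 log units; within the scatter); a 1.3-fold lower number from compound 2 to compound 4 (0.12 log units; within the scatter)). Compound 1 stays apart (a 3.7-fold lower number from compound 1 to compound 4 (0.56 log units; beyond the scatter)), so among these compounds a six-membered aromatic ring of carbon only does not by itself go with the higher number, since compound 4 carries such a ring too. No supporting measurement is available to explain why compounds 2, 3 and 4 fall together.

The compounds shown leave open whether phenylsulfanyl would sit with compound 1 or with the other three, which would test the atom linking the ring to the chain carbon. They also leave open whether a simple amine or a carboxylic acid at this place would stay with compounds 2, 3 and 4.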